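A few compounds are considered here, and "the series" means these few. Any claim that something is new, unique, unknown or untested is made for them only; others in the source may bear on it.

Measured so far in a functional assay on isolated protein for inhibition of Glucose-dependent insulinotropic receptor (Homo sapiens), read by HTRF and cAMP accumulation; on this read-out lower numbers stand for an effect already at smaller amounts and higher numbers for an effect only at larger amounts of compound:
Compound 1 `Cc1nc(S(C)(=O)=O)ccc1Oc1ncnc(OC2CCN(C(=O)OC(C)F)CC2)c1F` gives 65.5 nM.
Compound 2 `CCC(F)(F)C(=O)N1CCC(Oc2ncnc(Oc3ccc(S(C)(=O)=O)nc3C)c2F)CC1` gives 17.4 nM.

Among the compounds with values here, compound 2 holds the lowest number of the two in this assay; the only other measured compound, compound 1, sits at a higher number, and the gap between them is beyond the scatter. Within the data shown here, the single measured step, a 3.8-fold lower number from compound 1 to compound 2 (0.58 log units; beyond the scatter), also exchanges the group on the carbonyl carbon that joins the amide-type nitrogen in the ring, so it is the only step that bears on the next change.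

Compound 3 `Cc1nc(S(C)(=O)=O)ccc1Oc1ncnc(OC2CCN(C(=O)C3(C)CC3)CC2)c1F` differs from compound 2 by 1-methylcyclopropyl in place of 1,1-difluoropropyl on a carbonyl carbon. Among the measured compounds shown here, nothing measured here tells which way a group without fluorine on this carbonyl carbon moves the number; the one precedent shows that a change at this position can shift the number by a modest amount. A step of similar size in either direction is therefore possible, with no firm reason to expect compound 3 to come in lower than compound 2. Compound 3 is expected to land somewhat weaker than compound 2, a step of a 1.7-fold higher number from compound 2 to compound 3 (0.24 log units; within the scatter). The estimate for compound 3 in this assay is 30 nM, with a range from 8 nM to 110 nM.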

Compound 3, half-maximal effective concentration: 761 nM
For compound 3 the middle estimate is 25-fold (1.40 log units) below the measured one; the measured number lies above the stated range.
By their numbers in this assay, from the lowest: compound 2; then compound 1; then compound 3.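

In this assay, this position on the carbonyl carbon proves far less tolerant than the earlier modest step suggested: 1-methylcyclopropyl in place of 1,1-difluoropropyl gives a 44-fold higher number from compound 2 to compound 3 (1.64 log units; beyond the scatter), a large change from a swap of two small groups that carry no hydrogen-bond donors or acceptors and no net charge. The same group also compares poorly with the one on compound 1, with a 12-fold higher number from compound 1 to compound 3 (1.07 log units; beyond the scatter), so among these three compounds both groups that carry fluorine stand at lower numbers than the carbon-only group, and none of the three goes against this. Nothing measured here accounts for the size of this change.

The step removes fluorine and introduces a three-membered ring at once, and the compounds shown do not separate these two changes, so it remains open which of them goes with the higher number. A 1-fluorocyclopropyl group and an open-chain tert-butyl group on this carbonyl carbon would each isolate one of the two changes and show whether the ring or the loss of fluorine tracks with the shift.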